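From compound 3 to compound 4: an expected cytotoxicity

The compounds below may be only part of what the source reports. "The series", "measured", "known", "first", "only" and "open" are said of these compounds alone.

Of the compounds shown here, three sharing one core have been measured in an ADME assay on CEM-SS cells (Homo sapiens) for cytotoxicity, read by XTT assay, with a stated time of 6 days; a higher number here means that more compound is tolerated, a lower number that less compound is tolerated. Compound 1 `CCCC(=O)OCSc1ccccc1C(=O)NC1(C(N)=O)CCCC1` reports > 100 uM, which is a limit of the assay and not a number. Compound 2 `CCCC(=O)OCSc1ccccc1C(=O)NCCCNC(C)=O` gives 21.1 uM. Compound 3 `CCCC(=O)OCSc1ccccc1C(=O)N(C)CC(=O)NC` gives 62.5 uM, the higher of the two actual numbers, with compound 2 the nearest value.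

In compound 4 `C#CCNC(=O)CNC(=O)c1ccccc1SCOC(=O)CCC`, ((propargylcarbamoyl)methyl)amino stands in place of methyl((methylcarbamoyl)methyl)amino on a carbonyl carbon (((propargylcarbamoyl)methyl)amino in place of methyl((methylcarbamoyl)methyl)amino on a carbonyl carbon). Two measured steps also altered the group carried at this carbonyl. One is an at least 4.7-fold lower number from compound 1 to compound 2 (0.67 log units; beyond the scatter), whose size rests on a limit, and the other is a 3.0-fold higher number from compound 2 to compound 3 (0.47 log units; beyond the scatter). They run in opposite directions and neither is large, so they set no direction for the new change, and no step beyond the scatter is expected in this assay. The estimated change is a 1.3-fold lower number from compound 3 to compound 4 (0.10 log units; within the scatter). Compound 4 is expected at about 50 uM, with an estimated range of 20 uM to 110 uM.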

Compound 4, half-maximal toxic concentration: 95.4 uM
Estimate against measurement, compound 4: 1.9-fold (0.28 log units) below, within the range that was stated.
By their numbers in this assay, from the lowest: compound 2; then compounds 3 and 4 (each within the scatter of the next). At a limit, above all of these: compound 1.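

In this assay, replacing methyl((methylcarbamoyl)methyl)amino with ((propargylcarbamoyl)methyl)amino on a carbonyl carbon gives a 1.5-fold higher number from compound 3 to compound 4 (0.18 log units; within the scatter). This swap brings in a triple bond and one more hydrogen-bond donor, and the step stays within the scatter. The comparison with the 3-acetamidopropyl series member gives a 4.5-fold higher number from compound 2 to compound 4 (0.66 log units; beyond the scatter), which leaves compound 2 apart from both compound 3 and compound 4 in this assay. Compound 1 stands at a limit and not a number: the limit of > 100 uM in this assay, at which 1 of the 4 values shown sits. Measured against that limit, (propargylcarbamoyl)methyl in place of 1-carbamoylcyclopentyl on an amide-type nitrogen gives an at least 1.0-fold lower number from compound 1 to compound 4 (0.02 log units; that floor lies within the scatter), and the true size of this step cannot be read.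

The compounds shown do not separate the loss of the nitrogen methyl from the arrival of the propargyl group, since the two differ together. They also leave open how this position would respond to an amine, a carboxylic acid or a longer chain at the end of the amide.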